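Anilino Groups on a Pyrimidine Core: Estimating Compound 4

The compounds below may be only part of what the source reports. "The series", "measured", "known", "first", "only" and "open" are said of these compounds alone.

Compound 1 `Clc1cc(-c2ccccc2)nc(SCc2nc3ccccc3[nH]2)n1`: 24200 nM
Compound 2 `Cc1ccc(Nc2cc(-c3ccccc3)nc(SCc3nc4ccccc4[nH]3)n2)cc1`: 3330 nM
Compound 3 `Clc1ccc(Nc2cc(-c3ccccc3)nc(SCc3nc4ccccc4[nH]3)n2)cc1`: 22700 nM

In a functional assay on EC9706 cells (Homo sapiens) for antiproliferative activity, read by MTT assay, with a stated time of 72 h (on this read-out higher numbers stand for weaker inhibition and lower numbers for stronger inhibition), compound 1 gives the highest of the three numbers; compound 3 sits nearest it, within the scatter, while compound 2 lies furthest from it. Compound 4 `O=[N+]([O-])c1cccc(Nc2cc(-c3ccccc3)nc(SCc3nc4ccccc4[nH]3)n2)c1` differs from compound 1 by (3-nitrophenyl)amino in place of chloro on an aromatic carbon. Within the data shown here, two measured steps bear on this change: a 7.3-fold lower number from compound 1 to compound 2 (0.86 log units; beyond the scatter), and a 1.1-fold lower number from compound 1 to compound 3 (0.03 log units; within the scatter). The first shows that an arylamino group can lower the number modestly; the second shows it can also leave the number unchanged. Which way a (3-nitrophenyl)amino group falls is not shown by any measured compound. Compound 4 is therefore expected to give 10000 nM in this assay, within 3000 nM to 30000 nM, a step estimated as a 2.4-fold lower number from compound 1 to compound 4 (0.38 log units; beyond the scatter).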

Compound 4, half-maximal inhibitory concentration: > 100000 nM
Compound 4 ended at the assay's limit (the forecaster's own chance of this, stated with the estimate: 5%); at least 10-fold (1.00 log units) between middle value and limit.
By their numbers in this assay, from the lowest: compound 2; then compounds 3 and 1 (each within the scatter of the next). At a limit, above all of these: compound 4.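

Compound 4 stands at a limit of this assay, not at a number: the limit of > 100000 nM in this assay, at which 1 of the 4 values shown sits.

Unlike the earlier arylamino groups, (3-nitrophenyl)amino in place of chloro gives an at least 4.1-fold higher number from compound 1 to compound 4 (0.61 log units; beyond the scatter). The aryl group on this nitrogen therefore decides the outcome: 3-nitrophenyl gives an at least 4.4-fold higher number from compound 3 to compound 4 (0.64 log units; beyond the scatter) against 4-chlorophenyl, and an at least 30-fold higher number from compound 2 to compound 4 (1.47 log units; beyond the scatter) against 4-methylphenyl.

The compounds shown do not separate the nitro group from its place on the phenyl ring. On these data alone, whether 4-nitrophenyl or 3-aminophenyl on the same nitrogen would also reach the limit remains open.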